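The source may report more compounds than this note shows. Statements on the series, on what has been measured and on what is new or still open speak of the compounds shown alone.

Measured so far, in a functional assay on T47D cells (Homo sapiens) for antiproliferative activity, read by MTT assay, with a stated time of 48 h; on this read-out lower numbers stand for stronger inhibition and higher numbers for weaker inhibition:

compound 1 `O=C(Nc1ccccc1)Nc1nnc(Sc2ncnc3scc(-c4ccncc4)c23)s1`, which gives 23300 nM

compound 2 `O=C(Nc1cccc(C(F)(F)F)c1)Nc1nnc(Sc2ncnc3scc(-c4ccncc4)c23)s1`, which gives 45100 nM

compound 3 `O=C(Nc1ccc(Cl)cc1)Nc1nnc(Sc2ncnc3scc(-c4ccncc4)c23)s1`, which gives 23300 nM

Compound 4 `O=C(Nc1ccc(Cl)c(C(F)(F)F)c1)Nc1nnc(Sc2ncnc3scc(-c4ccncc4)c23)s1` has not yet been measured. It differs from compound 3 by trifluoromethyl in place of hydrogen on an aromatic carbon. The same change has been made once before, from compound 1 to compound 2, where it is trifluoromethyl in place of hydrogen on an aromatic carbon and gave a 1.9-fold higher number from compound 1 to compound 2 (0.29 log units; within the scatter). The two starting points are not identical: compound 3 differs from compound 1 by chloro in place of hydrogen on an aromatic carbon. The place where the trifluoromethyl enters therefore reads differently in the two pairs: ortho to a chloro group in compound 4, while in compound 2 it is meta to a large group only. The change is thus the same kind of change rather than the same one. Among the measured compounds shown here, with only one earlier example, the step from compound 3 to compound 4 in this assay is expected to be about a 1.5-fold higher number from compound 3 to compound 4 (0.18 log units; within the scatter), resting on the step that a 1.9-fold higher number from compound 1 to compound 2 (0.29 log units; within the scatter) showed. On that basis compound 4 is estimated to give 35000 nM, with a plausible range from 14000 nM to 90000 nM.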

Compound 4, half-maximal inhibitory concentration: 28000 nM
For compound 4 the middle estimate is 1.3-fold (0.10 log units) above the measured one; the measured number falls inside the stated range.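

In this assay, trifluoromethyl in place of hydrogen gives a 1.2-fold higher number from compound 3 to compound 4 (0.08 log units; within the scatter), and this step agrees with its earlier counterpart on the core without the chloro group: the same change on two cores in this assay, a 1.9-fold higher number (0.29 log units; within the scatter) from compound 1 to compound 2 and a 1.2-fold higher number (0.08 log units; within the scatter) from compound 3 to compound 4, 1.6-fold (0.21 log units) apart, within the scatter of two such steps. Chloro in place of hydrogen, carried onto the compound that already holds trifluoromethyl, gives a 1.6-fold lower number from compound 2 to compound 4 (0.21 log units; within the scatter), again in line with its earlier counterpart: the same change on two cores in this assay, no change at the digits printed (within the scatter) from compound 1 to compound 3 and a 1.6-fold lower number (0.21 log units; within the scatter) from compound 2 to compound 4, 1.6-fold (0.21 log units) apart, within the scatter of two such steps. Among the compounds shown here, with both groups in place, the outcome is a 1.2-fold higher number from compound 1 to compound 4 (0.08 log units; within the scatter), so neither change reads differently from one core to the other, but every step here lies within the scatter, which means these four compounds show only that the steps are small, not that a larger step would carry across cores in the same way.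

The compounds shown leave open whether an amine, a carboxylic acid or a longer alkyl chain on the phenyl ring would give a step beyond the scatter, and whether that step would hold on a second core. They also leave open what a change to the shared core itself would do.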